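The source may report more compounds than this note shows. Statements on the series, on what has been measured and on what is new or still open speak of the compounds shown alone.

Compound 1 `COc1ccc(C(=O)Nc2cccc(-c3ccnc4c(NC(C)=O)cccc34)c2)cc1OC` and compound 2 `CC(=O)Nc1cccc2c(-c3cccc(NC(=O)c4ccc(C(F)(F)F)c(Cl)c4)c3)ccnc12` share the same core and differ only in the aromatic group attached to the amide carbonyl. In a functional assay on A375P cells (Homo sapiens) for antiproliferative activity, read by MTT assay, with a stated time of 48 h (on this read-out higher numbers stand for weaker inhibition and lower numbers for stronger inhibition), compound 1 gives 5300 nM, and in this assay compound 2 gives 7600 nM. The step of a 1.4-fold higher number from compound 1 to compound 2 (0.16 log units; within the scatter) is small, so the two compounds cannot be ordered against each other. On the numbers at hand compound 2 holds the highest value of the two, with compound 1 nearest.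

Compound 3 `CC(=O)Nc1cccc2c(-c3cccc(NC(=O)c4cc(C)oc4C)c3)ccnc12` is not yet measured. It differs from compound 2 as follows: 2,5-dimethylfuran-3-yl in place of 3-chloro-4-(trifluoromethyl)phenyl on a carbonyl carbon. Among the measured compounds shown here, the only measured step, a 1.4-fold higher number from compound 1 to compound 2 (0.16 log units; within the scatter), shows that swapping one aromatic group on this carbonyl carbon for another left the number within the scatter. For the measured compounds named here, that step is the sole guide, so the step of a 1.1-fold higher number from compound 2 to compound 3 (0.02 log units; within the scatter) is expected to be small as well, with no direction beyond the scatter. Compound 3 is therefore estimated to give 8000 nM in this assay, likely between 3000 nM and 25000 nM.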

Compound 3, half-maximal inhibitory concentration: > 20000 nM
Compound 3 ended at the assay's limit (the forecaster's own chance of this, stated with the estimate: 15%); at least 2.5-fold (0.39 log units) between middle value and limit.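

Among the compounds shown, the group on this carbonyl carbon first makes a readable difference with 2,5-dimethylfuran-3-yl, which gives an at least 2.6-fold higher number from compound 2 to compound 3 (0.42 log units; beyond the scatter) and an at least 3.7-fold higher number from compound 1 to compound 3 (0.57 log units; beyond the scatter). The position is therefore not indifferent to the aromatic group it carries: in this assay, the five-membered ring with one hetero atom goes with weaker inhibition than either phenyl group, although the two phenyl groups could not be told apart. The value of compound 3 is a limit and not a number: the limit of > 20000 nM in this assay, at which 1 of the 3 values shown sits.

The ring size, the ring oxygen and the two methyl groups all enter in one change, and the data do not separate them. Also open, on these data alone, is how a furan ring without methyl groups, a pyridine ring or a plain phenyl ring on this carbonyl carbon would read.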